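The source may hold more compounds than are shown below. What is called first, only, known or untested is meant among the compounds shown, and "the series" means these compounds.

Measured so far in a functional assay on MDA-MB-231 cells (Homo sapiens) for antiproliferative activity, read by MTT assay, with a stated time of 72 h; a higher number here means a weaker inhibitor, a lower number a stronger inhibitor:
- compound 1 `CC1=CC[C@H]2[C@H](CC[C@]2(C)O)C(C)(C)[C@@H]1CC[C@H]1[C@]2(C)CC[C@H](OC(=O)c3ccccc3)C(C)(C)O[C@H]2CC[C@@]1(C)O`: 16100 nM
- compound 2 `CC1=CC[C@H]2[C@@H]1CC=C(C)[C@@H](CC[C@H]1[C@]3(C)CC[C@H](OC(=O)CCC(=O)O)C(C)(C)O[C@H]3CC[C@@]1(C)O)C2(C)C`: 29600 nM
- compound 3 `CC1=CC[C@H]2[C@@H]1CC=C(C)[C@@H](CC[C@H]1[C@]3(C)CC[C@H](OCc4ccccc4)C(C)(C)O[C@H]3CC[C@@]1(C)O)C2(C)C`: 35700 nM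

In this assay compound 1 gives the lowest of the three numbers. Compound 2 lies nearest to it, within the scatter, and compound 3 lies furthest, beyond it, so compound 1 and compound 2 cannot be ordered against each other on these data. Within the data shown here, the only step between measured compounds that differ in a single place is a 1.2-fold higher number from compound 2 to compound 3 (0.08 log units; within the scatter), a swap of benzyl in place of (2-carboxyethyl)carbonyl on an oxygen on a saturated carbon; it stayed within the scatter.

Compound 4 `CC1=CC[C@H]2[C@H](CC[C@]2(C)O)C(C)(C)[C@@H]1CC[C@H]1[C@]2(C)CC[C@H](OC(=O)c3cccc([N+](=O)[O-])c3)C(C)(C)O[C@H]2CC[C@@]1(C)O` is not yet measured. It differs from compound 1 by nitro in place of hydrogen on an aromatic carbon. Among the measured compounds shown here, no measured step touches the aromatic ring of the benzoyl group, and the one step at hand, a change of the whole group on that oxygen, was itself within the scatter. The expectation for this assay is therefore a step of no size beyond the scatter, in no set direction: the expected step is a 1.0-fold lower number from compound 1 to compound 4 (0.00 log units; within the scatter). For compound 4 the estimated value is 16000 nM, with a range from 6000 nM to 42000 nM.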

Compound 4, half-maximal inhibitory concentration: 34700 nM
The estimate for compound 4 lay 2.2-fold (0.34 log units) below the measured number; measured number inside the range.
By their numbers in this assay, from the lowest: compounds 1, 2, 4 and 3 (each within the scatter of the next, the first and the last beyond it).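

In this assay the aromatic ring of the benzoyl group proves responsive to change: nitro in place of hydrogen on an aromatic carbon, meta to a large group, gives a modest step (a 2.2-fold higher number from compound 1 to compound 4 (0.33 log units; beyond the scatter)) that lies beyond the scatter. Among these compounds, the only earlier step (a 1.2-fold higher number from compound 2 to compound 3 (0.08 log units; within the scatter)) replaced the whole group on that oxygen and stayed within the scatter, so it gave no sign that a single substituent on the ring could register. Nothing measured on these compounds accounts for the step.

Going by these compounds, whether the step belongs to nitro itself or would follow any group at this place remains open, and an amine or a carboxylic acid on the same aromatic carbon would test this. Also open, on these data alone, is whether a 3-nitrophenyl group gives a similar step on the core of compound 3.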